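Two pyrrolidine amides and a halogen swap on the far ring

This account rests on a few compounds, and the source may have more. Where it says the series, first, only, none or still open, it means among the compounds named here.

The study concerns inhibition of the acid amidase measured in an assay on HEK293 cells for inhibition of N-acylethanolamine-hydrolyzing acid amidase (Rattus norvegicus), read by LC-MS, with a stated time of 30 min; on this read-out lower numbers stand for stronger inhibition and higher numbers for weaker inhibition. Compound 1 `Cc1cccc(CCCCCCC(=O)N2CCCC2)c1` carries a seven-carbon chain between the amide and a methyl-substituted ring; in this assay compound 1 gives 8300 nM. Compound 2 `O=C(CCc1ccc(-c2ccccc2F)cc1)N1CCCC1` shortens the chain to three carbons and places a 2-fluorophenyl on the far ring; in this assay compound 2 gives 2800 nM. Of the two numbers recorded, compound 2 stands at the lowest, and the number of compound 1 lies higher by a gap that exceeds the ordinary scatter, so compound 2 is the stronger inhibitor of the pair.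

The next compound, compound 3 `O=C(CCc1ccc(-c2ccc(Cl)cc2)cc1)N1CCCC1`, differs from compound 2 in a single place: 4-chlorophenyl in place of 2-fluorophenyl on an aromatic carbon. Going by the values given here, no measured pair in this set shows what such a change does, so the expectation rests on compound 2 alone. The step from compound 2 to compound 3 is expected to be small, a 1.6-fold lower number from compound 2 to compound 3 (0.19 log units; within the scatter), at or near the edge of the scatter, with a lean toward a lower number. Compound 3 is therefore estimated at 1800 nM in this assay, within a range from 600 nM to 5400 nM.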

Compound 3, half-maximal inhibitory concentration: 48600 nM
Compound 3: middle estimate off by 27-fold (1.43 log units), on the low side, and the stated range ends below it.
By their numbers in this assay, from the lowest: compound 2; then compound 1; then compound 3.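

In this assay the exchange of 2-fluorophenyl for 4-chlorophenyl brings a 17-fold higher number from compound 2 to compound 3 (1.24 log units; beyond the scatter), which shows that this far ring is not a place where such a swap passes quietly and that the change costs much of the inhibition. The size of the step stands out. The two groups match in everything counted: each has the same number of heavy atoms, a single six-membered aromatic ring of carbon only, no hydrogen-bond donors or acceptors, and no net charge, and these counts do not predict the outcome here. Nothing measured in this set accounts for the loss of inhibition.

The swap alters both the halogen and its place on the ring, so the compounds shown leave open whether the step follows the chlorine or the position, a question that 2-chlorophenyl and 4-fluorophenyl would separate. They also leave open how an unsubstituted phenyl, or a methoxy group or a nitrile on this ring, would read.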